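The source may hold more compounds than are shown below. What is called first, only, known or untested is meant among the compounds shown, and "the series" means these compounds.

Three compounds of the series share one core, carried through with a butoxyphenyl group. Compound 1 `CCCCOc1ccc(-c2nc3ncccn3c2NCCC)cc1`, compound 2 `CCCCOc1ccc(-c2nc3ncccn3c2NCC2CC2)cc1` and compound 3 `CCCCOc1ccc(-c2nc3ncccn3c2N)cc1` have each been run in a toxicity assay on A549 cells (Homo sapiens) for cytotoxicity, read by luminescence and CellTiter-Glo, with a stated time of 48 h; a higher number here means that more compound is tolerated, a lower number that less compound is tolerated. For compound 1 the result is a limit of the assay, > 100000 nM. For compound 2 the result is likewise a limit, > 100000 nM. For compound 3 the result is again a limit, > 100000 nM. The steps a step that the two limits leave unreadable from compound 1 to compound 2, a step that the two limits leave unreadable from compound 1 to compound 3 and a step that the two limits leave unreadable from compound 2 to compound 3 cannot be sized, since all three values sit at the limit of > 100000 nM in this assay, at which 3 of the 3 values shown sit. Compound 4 `CCCCOc1ccc(-c2nc3ncccn3c2Nc2ccc(F)cc2)cc1` differs from compound 3 by 4-fluorophenyl in place of hydrogen on a nitrogen on an aromatic ring. Within the data shown here, no measured step touches this change. The estimate for compound 4 is 100000 nM, with a range from 40000 nM to 300000 nM. The expected step is a number no higher from compound 3 to compound 4 (the limit leaves the size open), that is, no change beyond the scatter is expected.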

Compound 4, half-maximal cytotoxic concentration: > 100000 nM
Compound 4 gave a limit, no number (the forecaster's own chance of this, stated with the estimate: 70%); the middle value lies on the limit itself.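

Among these compounds, compound 4 sits at a limit of the assay, as do compound 1, compound 2 and compound 3, so no step among them can be read in this assay: the limit of > 100000 nM in this assay, at which 4 of the 4 values shown sit. The compounds shown leave open whether any substituent on this nitrogen gives a readable value in this assay at all.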